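The source may report more compounds than this note shows. Statements on the series, on what has been measured and on what is new or still open speak of the compounds shown alone.

The compounds measured so far:

compound 1, `COc1ccc2nc(C)cc(OCC(=O)Nc3cc(C)cc(C)c3)c2c1`, 5.64
compound 2, `Cc1cc(C)cc(NC(=O)COc2cc(C)nc3ccc(C)cc23)c1`, 5.95
compound 3, `COc1ccc2nc(C)cc(OCC(=O)Nc3cc(C)c(OC)c(C)c3)c2c1`, 4.99

In a physicochemical assay for lipophilicity, read by HPLC, in phosphate buffer, measured as chromatographic lipophilicity, at pH 7.4 (a higher number here means a more lipophilic compound, a lower number a more polar compound), compound 1 gives 5.64, the second highest of the three numbers. Its nearest neighbour is compound 2, reached by a number 0.31 log units higher from compound 1 to compound 2 (beyond the scatter); the furthest is compound 3, reached by a number 0.65 log units lower from compound 1 to compound 3 (beyond the scatter).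

The unmeasured compound 4, `COc1ccc2nc(C)cc(OCC(=O)Nc3ccc(Cl)c(OC)c3)c2c1`, differs from compound 1 in one place: 4-chloro-3-methoxyphenyl in place of 3,5-dimethylphenyl on an amide-type nitrogen. Two of the measured steps bear on this change. The step from compound 1 to compound 3, a number 0.65 log units lower from compound 1 to compound 3 (beyond the scatter), introduced a methoxy on an aromatic carbon, and the step from compound 1 to compound 2, a number 0.31 log units higher from compound 1 to compound 2 (beyond the scatter), exchanged a methoxy for a methyl. Compound 4 gains a methoxy and a chlorine while losing two methyls, so a modest fall in this assay beyond the scatter is expected, estimated as a number 0.44 log units lower from compound 1 to compound 4 (beyond the scatter). Compound 4 is therefore expected to give about 5.2, within a range of 4.8 to 5.6.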

Compound 4, distribution coefficient: 5.09
Estimate against measurement, compound 4: 0.11 log units above; measured number inside the range.
By their numbers in this assay, from the lowest: compounds 3 and 4 (each within the scatter of the next); then compound 1; then compound 2.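

Placing 4-chloro-3-methoxyphenyl on the amide-type nitrogen in place of 3,5-dimethylphenyl gives, in this assay, a number 0.55 log units lower from compound 1 to compound 4 (beyond the scatter), so this position has now been seen with a ring that carries chlorine and neither methyl, and the step remains modest. Compound 3, which keeps both methyls and adds a methoxy, and compound 4 give numbers within the scatter of each other, so two differently substituted rings at this place cannot be told apart here. Nothing available explains the size of this step.

Going by these compounds, because the chlorine and the methoxy enter together while both methyls leave, the share of each group in the step remains open. On these data alone, how an amine or a carboxylic acid on this ring would read in this assay also remains open.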